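A few compounds are considered here, and "the series" means these few. Any claim that something is new, unique, unknown or untested is made for them only; others in the source may bear on it.

Measured so far:
compound 1 `Cc1ccc(C(=O)/C=C/c2ccc(/C=N/NC(=N)N)cc2)cc1` — in a functional assay on the whole organism (Ear) for inhibition, with Mus musculus as the target, with a stated time of 30 min, at a dose of 100 mg/kg by the intraperitoneal route (on this read-out lower numbers stand for less inhibition and higher numbers for more inhibition at the one dose given (going by the name of the read-out)), compound 1 gives 77.7%
compound 2 `O=C(N/N=C/c1ccc(/C=C/C(=O)c2ccccc2F)cc1)c1ccncc1` — in this assay compound 2 gives 51.3%

Of the two numbers shown, compound 1 stands highest; compound 2 lies a gap below it that is beyond the scatter. Compound 3 `N=C(N)N/N=C/c1ccc(/C=C/C(=O)c2ccc(F)cc2)cc1` is not yet measured. It differs from compound 1 by fluoro in place of methyl on an aromatic carbon. Among the compounds with values here, no measured pair shows this change alone, so its size is open; in this assay a small step, downward if any, or none beyond the scatter, is expected. For compound 3 the expected value is 70%, in the range 50% to 88%. The step this estimate means is a number 7.7 percentage points lower from compound 1 to compound 3 (within the scatter).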

Compound 3, a percentage reported as inhibition, in the whole organism at one dose (the size of the read-out at that dose, not a potency): 90.7%
Beside the measured number, compound 3's estimate is 20.7 percentage points below it; measured number outside the range, above it.
By their numbers in this assay, from the lowest: compound 2; then compound 1; then compound 3.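

In this assay, fluoro in place of methyl on an aromatic carbon, para to a large group, comes with a number 13 percentage points higher from compound 1 to compound 3 (beyond the scatter), so the read-out at the one dose given responds to a single-atom change at this position. The methyl group is therefore not required for a high read-out here. Nothing available gives a reason for this step. Open, as far as these compounds go, is how a chlorine, a methoxy group or an amine would read at this place. Also open, from the compounds shown here alone, is whether the same change holds on the core of compound 2, which differs from compound 1 in more than one place.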